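From 2-hydroxyphenyl to 4-acetylphenyl on the amide

The compounds below may be only part of what the source reports. "The series", "measured", "known", "first", "only" and "open" are said of these compounds alone.

Going by the values given here, in a functional assay on KB cells (Homo sapiens) for cytotoxicity, read by MTT assay (on this read-out lower numbers stand for stronger inhibition and higher numbers for weaker inhibition), compound 1 `CCn1cc(C(=O)Nc2ccccc2O)c(=O)c2cc(F)c(N3CCNC(C)C3)c(F)c21` gives 5050 nM, the higher of the two numbers measured so far. Compound 2 `CCn1cc(C(=O)Nc2cccc([N+](=O)[O-])c2)c(=O)c2cc(F)c(N3CCNC(C)C3)c(F)c21` gives 1700 nM. Compound 3 `CCn1cc(C(=O)Nc2ccc(C(C)=O)cc2)c(=O)c2cc(F)c(N3CCNC(C)C3)c(F)c21` keeps the core of compound 1 and changes one group, 4-acetylphenyl in place of 2-hydroxyphenyl on an amide-type nitrogen.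

Among the compounds with values here, only one measured step bears on this change. It is a 3.0-fold lower number from compound 1 to compound 2 (0.47 log units; beyond the scatter), a modest step in which 3-nitrophenyl takes the place of the same 2-hydroxyphenyl group. Within the data shown here, no measurement yet shows what 4-acetylphenyl itself does, so this single step is a weak guide. A similarly modest move towards lower numbers seems likeliest, and a result within the scatter would be no surprise. The expected change is a 2.3-fold lower number from compound 1 to compound 3 (0.36 log units; beyond the scatter). For compound 3 the estimated value in this assay is 2200 nM, with an expected range from 900 nM to 5500 nM.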

Compound 3, half-maximal inhibitory concentration: 42600 nM
Estimate against measurement, compound 3: 19-fold (1.29 log units) below; the whole stated range lies below it.
By their numbers in this assay, from the lowest: compound 2; then compound 1; then compound 3.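

Changing the group on the amide nitrogen can move the number in either direction: the 3-nitrophenyl step went down, but in this assay 4-acetylphenyl gives an 8.4-fold higher number from compound 1 to compound 3 (0.93 log units; beyond the scatter) and so goes up. The gap between the two new neighbours is wider still (a 25-fold higher number from compound 2 to compound 3 (1.40 log units; beyond the scatter)), so two substituted phenyl groups on the same core can sit far apart, and compound 3 has the highest number of the three. Nothing measured here says what lies behind these differences.

The compounds shown leave open whether the acetyl group itself or its place on the ring drives the rise, which 3-acetylphenyl and 4-nitrophenyl could help to separate. Also open, as far as these compounds go, is how plain phenyl, or a phenyl ring carrying an amine or a carboxylic acid, would compare.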